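This account rests on a few compounds, and the source may have more. Where it says the series, first, only, none or still open, it means among the compounds named here.

Measured compounds:
Compound 1, `O=C(Nc1cc(C(F)(F)F)cc(C(F)(F)F)c1)c1cc(Cl)c(-c2ccccc2)cc1O`, in a functional assay on NALM-6 cells (Homo sapiens) for cytotoxicity, read by luminescence and CellTiter-Glo, with a stated time of 3 days (a lower number here means a stronger inhibitor, a higher number a weaker inhibitor), compound 1 gives 560 nM.
Compound 2, `N#Cc1cc(Cl)ccc1NC(=O)c1ccc2cccnc2c1O`, in this assay compound 2 gives 280 nM.

Compound 2 has the lower of the two numbers, but the gap to compound 1 lies within the usual scatter, so the two cannot be ranked against each other. For the measured compounds named here, the two compounds differ in several places, so no single structural step connects them, and nothing beyond their two values can be said of the pair.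

Compound 3, `O=C(Nc1ccc(Cl)cc1)c1ccc2cccnc2c1O`, is not yet measured. It is obtained from compound 2 by one change: hydrogen in place of cyano on an aromatic carbon. Going by the values given here, no measured pair shows a step of this kind, so there is no direct guide to its size. A moderate weakening is expected in this assay, the step of a 2.5-fold higher number from compound 2 to compound 3 (0.40 log units; beyond the scatter), with the possibility that the change stays inside the scatter. Compound 3 is therefore estimated at 700 nM, within a range from 250 nM to 2500 nM.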

Compound 3, half-maximal inhibitory concentration: 380 nM
The estimate for compound 3 lay 1.8-fold (0.27 log units) above the measured number; low and high end bracket the measured number.
By their numbers in this assay, from the lowest: compounds 2, 3 and 1 (each within the scatter of the next).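

For the compounds shown here, at this position, on an aromatic carbon ortho to a large group and meta to a chloro group, this assay gives the first direct reading of the cyano group: replacing it with hydrogen produces a 1.4-fold higher number from compound 2 to compound 3 (0.13 log units; within the scatter) and so no change that can be told apart from the scatter. Within this pair, the nitrile is therefore not required for a value in this range, and compound 3 keeps the remaining structure of compound 2 without a distinguishable loss. Nothing available explains why the step is this small.

Going by these compounds, it remains open whether an amine, a carboxylic acid or a methoxy group at this same carbon would shift the number beyond the scatter. The compounds shown also leave open how replacing the chloro group with hydrogen or a bromo group would register here.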